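Replacing the sulfonyl link with a benzoyl group

The source may report more compounds than this note shows. Statements on the series, on what has been measured and on what is new or still open speak of the compounds shown alone.

Compound 1 `Cc1c(Cc2ccc(C(F)(F)F)cc2S(=O)(=O)c2ccccc2)c2c(n1CC(=O)O)CCNC2=O` and compound 2 `Cc1c(Cc2ccccc2S(=O)(=O)c2cccc(Cl)c2)c2c(n1CC(=O)O)CCNC2=O` share one core and have both been run in a functional assay on CHO.K1 cells for antagonist activity at prostaglandin D2 receptor 2 (Homo sapiens), read by GTPgammaS binding, with a stated time of 1 h; a higher number here means a weaker inhibitor, a lower number a stronger inhibitor. Compound 1 gives 13 nM, while compound 2 gives 4 nM, the lower of the two numbers, and the gap between them lies beyond the scatter. Compound 3 `Cc1c(Cc2ccccc2C(=O)c2ccccc2)c2c(n1CC(=O)O)CCNC2=O` is not yet measured; it differs from compound 2 by benzoyl in place of (3-chlorophenyl)sulfonyl on an aromatic carbon. Among the measured compounds shown here, no measured pair carries this change, so its size is unknown here; a modest rise in this assay is expected, near the edge of the scatter, as the step of a 5.0-fold higher number from compound 2 to compound 3 (0.70 log units; beyond the scatter). For compound 3 the estimate in this assay is 20 nM, with a range of 6 nM to 70 nM.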

Compound 3, half-maximal inhibitory concentration: 810 nM
Beside the measured number, compound 3's estimate is 41-fold (1.61 log units) below it; measured number outside the range, above it.
By their numbers in this assay, from the lowest: compound 2; then compound 1; then compound 3.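

In this assay, the aromatic carbon ortho to a large group proves highly sensitive to this change: benzoyl in place of (3-chlorophenyl)sulfonyl gives a 200-fold higher number from compound 2 to compound 3 (2.31 log units; beyond the scatter). The swap alters the link and removes the chlorine together, so this single step belongs to the whole group and not to either part. Nothing available accounts for the size of the step.

Open, going by these compounds, is how much of the step follows the link and how much the chlorine; a 3-chlorobenzoyl group at this place would separate the two. Also open, on these data alone, is how a sulfonamide link would read here.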